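The source may report more compounds than this note shows. Statements on the series, on what has been measured and on what is new or still open speak of the compounds shown alone.

In a functional assay on MDA-MB-231 cells (Homo sapiens) for antiproliferative activity, read by luminescence, with a stated time of 24 h (on this read-out lower numbers stand for stronger inhibition and higher numbers for weaker inhibition), compound 1 (`CC(=O)NCCNC(=O)CCC(=O)Oc1c(C)c(C)c2c(c1C)CCC(C)(COc1ccc(/C=C3\SC(=O)NC3=O)cc1)O2`) gives > 25000 nM as a limit of the assay, not a number. Going by the values given here, compound 2 (`Cc1c(C)c2c(c(C)c1OC(=O)CCCCCCCNC(=O)OC(C)(C)C)CCC(C)(COc1ccc(/C=C3\SC(=O)NC3=O)cc1)O2`) gives 3200 nM in this assay and holds the only number so far. Compound 3 (`Cc1c(C)c2c(c(C)c1OC(=O)CCCC[C@@H]1SC[C@@H]3NC(=O)N[C@@H]31)CCC(C)(COc1ccc(/C=C3\SC(=O)NC3=O)cc1)O2`) differs from compound 2 by one change (a group of 9 heavy atoms (5 carbon, 2 nitrogen, 1 oxygen, 1 sulfur; one five-membered non-aromatic ring with 1 hetero atom, one five-membered non-aromatic ring with 2 hetero atoms) in place of a group of 11 heavy atoms (8 carbon, 1 nitrogen, 2 oxygen; no ring), on a saturated chain carbon, four bonds along the chain from a carbonyl carbon), in which a group with two five-membered non-aromatic rings replaces a group with no ring, on a saturated chain carbon. Among the compounds with values here, no measured step is available, so with compound 2 at 3200 nM as the sole anchor, a moderate move toward weaker inhibition in this assay is expected (a 2.2-fold higher number from compound 2 to compound 3 (0.34 log units; beyond the scatter)). For compound 3 the estimated value is 7000 nM with a wide expected range (from 2000 nM to 25000 nM).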

Compound 3, half-maximal inhibitory concentration: 3500 nM
Beside the measured number, compound 3's estimate is 2.0-fold (0.30 log units) above it, and the stated range covers the measured number.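

In this assay, on a saturated chain carbon, four bonds along the chain from a carbonyl carbon, a group with two five-membered non-aromatic rings in place of 3-((tert-butoxycarbonyl)amino)propyl gives a 1.1-fold higher number from compound 2 to compound 3 (0.04 log units; within the scatter) and so leaves the read-out unchanged within the scatter. The other change, on a saturated chain carbon, two bonds along the chain from a carbonyl carbon, gives an at least 7.1-fold lower number from compound 1 to compound 3 (0.85 log units; beyond the scatter) as its step. Compound 1 stands at a limit of the assay, not a number: the limit of > 25000 nM in this assay, at which 1 of the 3 values shown sits.

As far as these compounds go, whether a free amine or a carboxylic acid at this position would read like compound 2 and compound 3 remains open.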